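Working notes: methoxycarbonyl to cyclohexyloxycarbonyl

The compounds below may be only part of what the source reports. "The series", "measured", "known", "first", "only" and "open" are said of these compounds alone.

- compound 1 (`CCNC(=O)Nc1sc2ccccc2c1C(=O)N1CCN(C2CCN(C(=O)CC(C)C)CC2)CC1`) gives "not determined" (no result reported)
- compound 2 (`CCNC(=O)Nc1sc2ccccc2c1C(=O)N1CCN(C2CCN(C(=O)C(C)(C)C)CC2)CC1`) gives 450 nM
- compound 3 (`CCNC(=O)Nc1sc2ccccc2c1C(=O)N1CCN(C2CCN(C(=O)OC)CC2)CC1`) gives "not determined" (no result reported)

All three entries come from a functional assay on HepG2 cells (Homo sapiens) for inhibition, read by scintillation counting, with a stated time of 2 h; on this read-out higher numbers stand for weaker inhibition and lower numbers for stronger inhibition. In this series, compound 3 has no single number on that read-out, and its entry stands as "not determined" (no result reported). Compound 1 also lacks a number. For the measured compounds named here, that leaves compound 2, at 450 nM, as the only numerical anchor, and no step between measured compounds is available.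

Compound 4 (`CCNC(=O)Nc1sc2ccccc2c1C(=O)N1CCN(C2CCN(C(=O)OC3CCCCC3)CC2)CC1`) has not yet been measured. The structural change is cyclohexyl in place of methyl on an oxygen next to a carbonyl group, with cyclohexyl in place of methyl on an oxygen next to a carbonyl group. The rest of the structure is unchanged.

With no number for compound 3, the size of this step in this assay cannot be read from the data. Going by the values given here, the working expectation is a moderate step toward stronger inhibition, but this is a judgement with no measured step behind it. Among the compounds with values here, the only numerical reference is compound 2 at 450 nM, so the range is kept wide.

For compound 4 the estimated value is 170 nM, with an expected range from 35 nM to 800 nM.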

Compound 4, half-maximal inhibitory concentration: 635 nM
Compound 4: middle estimate off by 3.7-fold (0.57 log units), on the low side, and the stated range covers the measured number.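

In this assay, cyclohexyloxy in place of tert-butyl on a carbonyl carbon gives a 1.4-fold higher number from compound 2 to compound 4 (0.15 log units; within the scatter), so compound 2 and compound 4 cannot be told apart on this read-out. This gives the position a second numerical anchor and shows that two different groups, one with an oxygen attached to the carbonyl carbon and a six-membered non-aromatic ring of carbon only, the other a tert-butyl, both leave a measurable inhibition in the same range, which compound 2 alone could not show. The steps to compound 1 and compound 3 cannot be read, since neither has a single number, and no measurement in hand says why the two measured compounds sit so close.

The shown compounds leave open how far this tolerance extends, including whether methoxy on the same carbonyl differs at all from cyclohexyloxy. Also open, on these data alone, is what a phenyl or a longer alkyl chain in place of cyclohexyl on the oxygen would do, or a basic amine or carboxylic acid carried on that ring.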